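The compounds below may be only part of what the source reports. "The series", "measured", "known", "first", "only" and "open" are said of these compounds alone.

Measured compounds:
compound 1, `Clc1ccc(-c2cc(-c3ccsc3)nc(-c3ccccc3Cl)c2)o1`, 4570 nM
compound 2, `Clc1ccc(-c2cc(-c3cccs3)nc(-c3ccccc3Cl)c2)o1`, 6190 nM
compound 3, `Clc1ccc(-c2cc(-c3ccoc3)cc(-c3cccs3)n2)cc1`, 50000 nM

In a functional assay on HCT-15 cells (Homo sapiens) for cytotoxicity, in the presence of a further agent that is not named here (a higher number here means a weaker inhibitor, a lower number a stronger inhibitor), compound 1 gives 4570 nM, compound 2 gives 6190 nM and compound 3 gives 50000 nM. Compound 1 and compound 2 share a core and differ by thiophen-3-yl in place of thiophen-2-yl on an aromatic carbon; this produced a 1.4-fold lower number from compound 2 to compound 1 (0.13 log units; within the scatter). The difference between the core of compound 2 and the core of compound 3 is not broken down here; their values show that compound 3 gives the higher number in this assay.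

Compound 4, `Clc1ccc(-c2cc(-c3ccoc3)cc(-c3ccsc3)n2)cc1`, is not yet measured. It differs from compound 3 by thiophen-3-yl in place of thiophen-2-yl on an aromatic carbon. Among the measured compounds shown here, this is the same kind of change as the one from compound 2 to compound 1, though not the same: around the place in compound 1 the groups are a 2-chlorophenyl group and a 5-chlorofuran-2-yl group, whereas around the place in compound 4 they are a 4-chlorophenyl group and a furan-3-yl group. Because the earlier step of a 1.4-fold lower number from compound 2 to compound 1 (0.13 log units; within the scatter) lay within the scatter, a small step is expected here too, estimated as a 1.3-fold lower number from compound 3 to compound 4 (0.10 log units; within the scatter). Compound 4 is therefore estimated at 40000 nM in this assay, between 15000 nM and 100000 nM.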

Compound 4, half-maximal inhibitory concentration: > 100000 nM
Compound 4 ended at the assay's limit; the forecaster's own chance of this, stated with the estimate: 40%; middle value at least 2.5-fold (0.39 log units) away from the limit.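

In this assay compound 4 gives > 100000 nM, and this is a limit of the assay, not a number. Read against the value of its thiophen-2-yl partner, that limit yields an at least 2.0-fold higher number from compound 3 to compound 4 (0.30 log units; that floor lies within the scatter), so although the floor of this step is itself small, replacing thiophen-2-yl with thiophen-3-yl did not give the same result on the two cores: the same change on two cores in this assay, a 1.4-fold lower number (0.13 log units; within the scatter) from compound 2 to compound 1 and an at least 2.0-fold higher number (0.30 log units; that floor lies within the scatter) from compound 3 to compound 4, at least 2.7-fold (0.43 log units) apart, beyond the scatter of two such steps This shows that the earlier step cannot simply be carried over to the core of compound 3, but it does not show the true size of the new step, or which of the groups that differ in the two cores accounts for the gap: the limit of > 100000 nM in this assay, at which 1 of the 4 values shown sits.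

The compounds shown leave open how the same change would behave on further cores within this series. They also leave open whether an amine or a carboxylic acid in place of the chlorine of the 4-chlorophenyl group would bring the thiophen-3-yl compound back within the measurable range of this assay.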